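The source may hold more compounds than are shown below. What is called first, only, known or untested is meant among the compounds shown, and "the series" means these compounds.

Within the data shown here, in a functional assay on SU-DHL-6 cells (Homo sapiens) for antiproliferative activity, read by CCK-8 assay, with a stated time of 72 h (a higher number here means a weaker inhibitor, a lower number a stronger inhibitor), compound 1 `COc1ncc(-c2ccc3ncnc(NCCN(C)C)c3c2)cc1NS(C)(=O)=O` gives 1700 nM, the highest number of the three measured so far. Compound 2 `COc1ncc(-c2ccc3ncnc(NCCN4CCCCC4)c3c2)cc1NS(C)(=O)=O` gives 320 nM, and compound 3 `COc1ncc(-c2ccc3ncnc(N[C@H]4CCN(C(=O)C5CCCC5)C4)c3c2)cc1NS(C)(=O)=O` gives 770 nM. Compound 4 `COc1ncc(-c2ccc3ncnc(N[C@H]4CCN(C(=O)C(C)(C)C)C4)c3c2)cc1NS(C)(=O)=O` carries 1-((tert-butyl)carbonyl)pyrrolidin-3-yl in place of 2-(dimethylamino)ethyl on a nitrogen on an aromatic ring. Among the measured compounds shown here, the closest precedent is a 2.2-fold lower number from compound 1 to compound 3 (0.34 log units; beyond the scatter), where 1-(cyclopentylcarbonyl)pyrrolidin-3-yl enters at that same place. The larger 5.3-fold lower number from compound 1 to compound 2 (0.73 log units; beyond the scatter) bears less directly, since it keeps the 2-carbon chain's replacement basic in name only as a piperidin-1-yl swap for dimethylamino. A similarly modest move toward a lower number is therefore expected, with the estimated step being a 2.3-fold lower number from compound 1 to compound 4 (0.36 log units; beyond the scatter). Compound 4 is estimated at 750 nM, within a range of 330 nM to 1700 nM.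

Correction to the sentence on the larger step, which should read: The larger 5.3-fold lower number from compound 1 to compound 2 (0.73 log units; beyond the scatter) bears less directly, since there piperidin-1-yl replaces dimethylamino on a saturated chain carbon.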

Compound 4, half-maximal inhibitory concentration: 7600 nM
Compound 4: the middle estimate sits 10-fold (1.01 log units) below what was measured, outside the stated range (above it).
By their numbers in this assay, from the lowest: compound 2; then compound 3; then compound 1; then compound 4.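

In this assay, the acyl group alone decides much of the outcome at this position: tert-butyl in place of cyclopentyl on a carbonyl carbon gives (a 9.9-fold higher number from compound 3 to compound 4 (0.99 log units; beyond the scatter)). Unlike compound 3, the 1-((tert-butyl)carbonyl)pyrrolidin-3-yl group on this nitrogen lands above the 2-(dimethylamino)ethyl compound (a 4.5-fold higher number from compound 1 to compound 4 (0.65 log units; beyond the scatter)) and far above the 2-(piperidin-1-yl)ethyl compound (a 24-fold higher number from compound 2 to compound 4 (1.38 log units; beyond the scatter)). Nothing at hand accounts for the gap between these two acyl groups.

As far as these compounds go, it remains open how an acetyl or cyclohexylcarbonyl group on the pyrrolidine nitrogen would fall relative to cyclopentylcarbonyl and tert-butylcarbonyl.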